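The source may report more compounds than this note shows. Statements on the series, on what has been measured and on what is new or still open speak of the compounds shown alone.

Measured compounds:
compound 1 `c1ccc(C2=NN(c3ccc(-c4ccccc4)nn3)C(c3ccccc3)C2)cc1` — 23800 nM
compound 2 `COc1cc(C2CC(c3ccccc3)=NN2c2ccc(-c3ccccc3)nn2)cc(OC)c1OC` — 70000 nM
compound 3 `Clc1ccc(C2=NN(c3ccc(-c4ccccc4)nn3)C(c3ccccc3)C2)cc1` — 10000 nM

In a functional assay on MCF7 cells (Homo sapiens) for antiproliferative activity, read by MTT assay, with a stated time of 24 h (a lower number here means a stronger inhibitor, a higher number a weaker inhibitor), compound 3 stands lowest of the three numbers; compound 1 sits above it and compound 2 furthest above it. Within the data shown here, the one single-point step measured so far, a 2.4-fold lower number from compound 1 to compound 3 (0.38 log units; beyond the scatter), is modest but beyond the scatter, and it is the only step in the set that changes a single aromatic substituent. Compound 2 differs from compound 1 in another place and is not a single step from compound 3; its value shows only that it gives a higher number than both.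

Compound 4 `FC(F)(F)c1ccc(C2CC(c3ccc(Cl)cc3)=NN2c2ccc(-c3ccccc3)nn2)cc1` differs from compound 3 by trifluoromethyl in place of hydrogen on an aromatic carbon. Among the measured compounds shown here, no measured step bears directly on this change. For the measured compounds named here, the nearest precedent, a 2.4-fold lower number from compound 1 to compound 3 (0.38 log units; beyond the scatter), concerned a different substituent on a different ring, so it gives direction only weakly. The expectation for compound 4 in this assay is therefore a step of no more than the size of no change at the digits printed from compound 3 to compound 4 (within the scatter), with little confidence in the direction. Compound 4 is estimated at 10000 nM, within 4000 nM to 25000 nM.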

Compound 4, half-maximal inhibitory concentration: 1670 nM
Beside the measured number, compound 4's estimate is 6.0-fold (0.78 log units) above it, outside the stated range (below it).
By their numbers in this assay, from the lowest: compound 4; then compound 3; then compound 1; then compound 2.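

In this assay, the change from phenyl to 4-(trifluoromethyl)phenyl gives a 6.0-fold lower number from compound 3 to compound 4 (0.78 log units; beyond the scatter) and thus shows that this aromatic carbon, para to a large group, is sensitive to substitution. Together with a 2.4-fold lower number from compound 1 to compound 3 (0.38 log units; beyond the scatter) there are now two single-substituent steps that lower the number beyond the scatter, although they involve different groups on different rings. Nothing shown here bears on why this step lowers the number.

Still open, as far as these compounds go, is whether the step is specific to trifluoromethyl or would also appear with a nitrile, an amine or a carboxylic acid on the same carbon. Also open, from the compounds shown here alone, is whether the step holds with hydrogen in place of the chloro of compound 3.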